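This account rests on a few compounds, and the source may have more. Where it says the series, first, only, none or still open, it means among the compounds named here.

Working notes on the series. Compound 2 `Cn1c(-c2ccc(NC(=O)CSc3nc4ccccc4s3)cc2)nc(-c2ccccc2)c1-c1ccccc1` is the point of departure; in a functional assay on MCF7 cells (Homo sapiens) for cytotoxicity, read by MTT assay, with a stated time of 24 h, tested at 1.6 ug/mL (on this read-out lower numbers stand for a weaker effect and higher numbers for a stronger effect at the one concentration tested), compound 2 gives 2.1%, the lowest of the three numbers measured, with compound 1 `Cn1c(-c2ccc(NC(=O)CSc3nc4cc(Cl)ccc4o3)cc2)nc(-c2ccccc2)c1-c1ccccc1` at 2.5% within the scatter of it, and compound 3 `Cn1c(-c2ccc(NC(=O)CSC3=NCCS3)cc2)nc(-c2ccccc2)c1-c1ccccc1` at 16.2% beyond the scatter above it. Compound 4 `CCN1CCN(CC(=O)Nc2ccc(-c3nc(-c4ccccc4)c(-c4ccccc4)n3C)cc2)CC1` is not yet measured. It differs from compound 2 by 4-ethylpiperazin-1-yl in place of (1,3-benzothiazol-2-yl)sulfanyl on a saturated chain carbon bound to a carbonyl carbon.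

Within the data shown here, two measured steps touch the same position. The step of a number 0.4 percentage points lower from compound 1 to compound 2 (within the scatter) swaps one aromatic group on the sulfur for another and stays within the scatter. The step of a number 14.1 percentage points higher from compound 2 to compound 3 (beyond the scatter) replaces the aromatic group with a small five-membered non-aromatic ring and gives a modest rise. Among the measured compounds shown here, neither step removes the sulfur itself, and no measured compound carries a six-membered non-aromatic ring with two hetero atoms at this place, so the change to compound 4 is only partly covered. On this basis compound 4 is expected to move as a number 7.9 percentage points higher from compound 2 to compound 4 (within the scatter) in this assay, a modest rise at most or none beyond the scatter. The estimated read-out for compound 4 is 10%, with a range from 0% to 28%.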

Compound 4, a percentage reported as activity, at one concentration (the size of the read-out at that concentration, not a potency): 14.6%
Beside the measured number, compound 4's estimate is 4.6 percentage points below it; the measured number falls inside the stated range.
By their numbers in this assay, from the lowest: compounds 2 and 1 (each within the scatter of the next); then compounds 4 and 3 (each within the scatter of the next).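

In this assay, a group without sulfur on a saturated chain carbon bound to a carbonyl carbon also lifts the read-out beyond the scatter: 4-ethylpiperazin-1-yl gives a number 12.5 percentage points higher from compound 2 to compound 4 (beyond the scatter) and, against (5-chloro-1,3-benzoxazol-2-yl)sulfanyl, a number 12.1 percentage points higher from compound 1 to compound 4 (beyond the scatter). The sulfur is therefore not required for the higher read-outs in this small set, and the step of a number 1.6 percentage points lower from compound 3 to compound 4 (within the scatter) does not separate the two non-aromatic rings. No measured data bear on the cause of these steps.

Since 4-ethylpiperazin-1-yl removes the sulfur and the aromatic rings together, the contribution of each remains unresolved. A morpholin-4-yl group, a diethylamino group or a longer chain on the same carbon would test how much of the step depends on the piperazine ring itself.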